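A few compounds are considered here, and "the series" means these few. Any claim that something is new, unique, unknown or untested is made for them only; others in the source may bear on it.

Working notes on the series. Compound 1 `COc1ccc(N(CC(=O)NCCC[Se]c2ccccc2)C(=O)c2ccccc2)cc1` is the benzoyl member. In a functional assay on MCF7 cells (Homo sapiens) for cytotoxicity, read by MTT assay, with a stated time of 24 h (a higher number here means a weaker inhibitor, a lower number a stronger inhibitor), compound 1 gives >= 100000 nM, which is a limit of the assay and not a number. Compound 2 `COc1ccc(N(CC(=O)NCCC[Se]c2ccccc2)C(=O)CNC(=O)OC(C)(C)C)cc1` carries the ((tert-butoxycarbonyl)amino)methyl group instead. In this assay compound 2 gives >= 100000 nM, again a limit. The step from compound 1 to compound 2 is therefore a step that the two limits leave unreadable from compound 1 to compound 2, and nothing about its size can be drawn from it. Compound 3 `COc1ccc(N(CC(=O)NCCCSc2ccccc2)C(=O)/C=C/c2ccccc2)cc1` is the cinnamoyl member with sulfur in the chain. In this assay compound 3 gives >= 100000 nM, once more a limit of the assay. Compound 3 thus stands at the limit of >= 100000 nM in this assay, at which 3 of the 3 values shown sit, so no value in the set so far is a real number.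

Compound 4 `COc1ccc(N(CC(=O)NCCC[Se]c2ccccc2)C(=O)/C=C/c2ccccc2)cc1` differs from compound 3 by a group of 7 heavy atoms (6 carbon, 1 selenium; one six-membered aromatic ring of carbon only) in place of a group of 7 heavy atoms (6 carbon, 1 sulfur; one six-membered aromatic ring of carbon only), on a saturated chain carbon, three bonds along the chain from an amide-type nitrogen. Going by the values given here, no measured step exchanges sulfur for selenium; the single measured step, from compound 1 to compound 2, concerns the group on the carbonyl carbon and is not readable. Among the compounds with values here, no size of step in this assay can therefore be read from the data; the expected step from compound 3 to compound 4 is a number no higher from compound 3 to compound 4 (the limit leaves the size open), within the scatter. Compound 4 is expected at 100000 nM, with a range of 30000 nM to 300000 nM, most likely reported as a limit rather than a number.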

Compound 4, half-maximal inhibitory concentration: >= 100000 nM
Compound 4 gave a limit, no number; the forecaster's own chance of this, stated with the estimate: 80%; the middle value sits exactly at the limit.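

In this assay compound 4 gives >= 100000 nM, a limit of the assay and not a number. The steps from compound 1, compound 2 and compound 3 to compound 4 therefore cannot be read: the limit of >= 100000 nM in this assay, at which 4 of the 4 values shown sit.

The compounds shown leave open how large any step in this assay is, whether for selenium in place of sulfur or for a change of the group on the carbonyl carbon.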